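From a Propyl Chain to a Methylcyclopropyl Ring

This account rests on a few compounds, and the source may have more. Where it says the series, first, only, none or still open, it means among the compounds named here.

Compound 1 `CCCC(=O)N1CC2CC(C1)N2` and compound 2 `O=C(C1CC=CC1)N1CC2CC(C1)N2` share one core and differ only in the group on the carbonyl carbon. In an assay on CHO cells for agonist activity at Neuronal acetylcholine receptor; alpha3/alpha6/beta2/beta3 (Homo sapiens), read by FLIPR and calcium flux (on this read-out higher numbers stand for larger maximal responses and lower numbers for smaller maximal responses), compound 1 gives 92%, the smaller of the two numbers, and compound 2 gives 99%; the gap lies within the usual scatter, so the two stand together. Compound 3 `C[C@H]1C[C@H]1C(=O)N1CC2CC(C1)N2` has not yet been measured. The change is 2-methylcyclopropyl in place of propyl on a carbonyl carbon. Because compound 1 already gives 92%, compound 3 is expected to stay near a full response, with a step of a number 3 percentage points higher from compound 1 to compound 3 (within the scatter) not beyond the scatter. The estimate for compound 3 is 95%, between 80% and 108%.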

Compound 3, largest response reached (Emax), in percent of the reference or control that the assay uses: 60%
Compound 3: middle estimate off by 35 percentage points, on the high side; the whole stated range lies above it.
By their numbers in this assay, from the lowest: compound 3; then compounds 1 and 2 (each within the scatter of the next).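

In this assay, putting 2-methylcyclopropyl in place of propyl on a carbonyl carbon gives a number 32 percentage points lower from compound 1 to compound 3 (beyond the scatter) with no change in hydrogen-bond donors, acceptors or charge, so this place does not accept every small carbon group. A ring alone does not go with such a loss: compound 2 gives 99% with a ring at this place too. No measurement at hand explains the drop. Still open, as far as these compounds go, is whether plain cyclopropyl or a longer chain such as butyl would keep the response, and how the mirror-image form of the 2-methylcyclopropyl group would behave.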